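A few compounds are considered here, and "the series" means these few. Any claim that something is new, unique, unknown or untested is made for them only; others in the source may bear on it.

Measured compounds:
- compound 1 (`O=C(Nc1ccccc1F)C(Cl)Cl`): "not determined" (no result reported)
- compound 2 (`O=C(Nc1cccc(Cl)c1)C(Cl)Cl`): 44500 nM

Among the compounds with values here, in a functional assay on Bel-7402 cells (Homo sapiens) for antiproliferative activity, read by MTT assay, with a stated time of 72 h (a lower number here means a stronger inhibitor, a higher number a weaker inhibitor), compound 2 gives 44500 nM and is the only compound with a number; compound 1 has no reported result there. Compound 3 (`O=C(Nc1cccc(OC(F)(F)F)c1)C(Cl)Cl`) differs from compound 2 by a single change: trifluoromethoxy in place of chloro on an aromatic carbon. Within the data shown here, no pair of measured compounds shows what such a change does, so the direction is open. The expected step, a 1.3-fold lower number from compound 2 to compound 3 (0.10 log units; within the scatter), stays within the usual scatter. Compound 3 is therefore estimated in this assay at 35000 nM, with a range from 12000 nM to 100000 nM.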

Compound 3, half-maximal inhibitory concentration: 10300 nM
For compound 3 the middle estimate is 3.4-fold (0.53 log units) above the measured one; measured number outside the range, below it.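

In this assay the swap of chloro for trifluoromethoxy on this aromatic carbon gives a 4.3-fold lower number from compound 2 to compound 3 (0.64 log units; beyond the scatter) and so moves the number beyond the usual scatter. This shows that the assay responds to what sits at this position, which a single measured compound could not show. No measurement at hand explains the shift.

This one pair cannot show which feature of trifluoromethoxy matters. On these data alone, how an amine or a carboxylic acid on the same carbon would compare also stays open.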